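This account rests on a few compounds, and the source may have more. Where it says the series, first, only, none or still open, it means among the compounds named here.

Of the compounds shown here, three sharing one core have been measured in an in vitro functional assay on cells for agonist activity at Bombesin receptor subtype-3 (Homo sapiens), read by luminescence and calcium flux; on this read-out higher numbers stand for an effect only at larger amounts of compound and lower numbers for an effect already at smaller amounts. Compound 1 `O=C(O)c1ccccc1-c1ccc(CCc2ncc(CC3CCC3)[nH]2)cc1` gives 588 nM, compound 2 `Cc1ccccc1Cc1cnc(CCc2ccc(-c3ccccc3C(=O)O)cc2)[nH]1` gives 127 nM, and compound 3 `O=C(O)c1ccccc1-c1ccc(CCc2ncc(Cc3ccc(Cl)cc3)[nH]2)cc1` gives 2290 nM. Compound 2 thus stands lowest of the three, with the nearest step being a 4.6-fold lower number from compound 1 to compound 2 (0.67 log units; beyond the scatter) and the furthest an 18-fold higher number from compound 2 to compound 3 (1.26 log units; beyond the scatter); the remaining step is a 3.9-fold higher number from compound 1 to compound 3 (0.59 log units; beyond the scatter). Compound 4 `CC(C)(C)c1cnc(CCc2ccc(-c3ccccc3C(=O)O)cc2)[nH]1` differs from compound 2 by tert-butyl in place of 2-methylbenzyl on an aromatic carbon. Within the data shown here, the group entering is smaller than either the cyclobutyl of compound 1 or the 2-methylbenzyl of compound 2, and no measured step covers such a change directly; since both moves away from 2-methylbenzyl raised the number, a rise is expected, estimated as a 7.9-fold higher number from compound 2 to compound 4 (0.90 log units; beyond the scatter). Compound 4 is therefore expected to give about 1000 nM, between 300 nM and 3500 nM.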

Compound 4, half-maximal effective concentration: 4330 nM
Beside the measured number, compound 4's estimate is 4.3-fold (0.64 log units) below it, outside the stated range (above it).
By their numbers in this assay, from the lowest: compound 2; then compound 1; then compounds 3 and 4 (each within the scatter of the next).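

Putting tert-butyl in place of 2-methylbenzyl on this aromatic carbon gives a 34-fold higher number from compound 2 to compound 4 (1.53 log units; beyond the scatter) and is the largest step seen at this position. Cyclobutylmethyl gives way to tert-butyl with a 7.4-fold higher number from compound 1 to compound 4 (0.87 log units; beyond the scatter) as the result, while the change from 4-chlorobenzyl gives a 1.9-fold higher number from compound 3 to compound 4 (0.28 log units; within the scatter) and stays within the scatter, so a six-membered aromatic ring on the chain does not by itself separate compound 3 from the ringless compound 4. No measurement shown here explains these steps. Still open, as far as these compounds go, is how unsubstituted benzyl, a 2-methoxybenzyl or an aminomethyl group would behave at this carbon.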